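A few compounds are considered here, and "the series" means these few. Any claim that something is new, unique, unknown or untested is made for them only; others in the source may bear on it.

In a functional assay on DU-145 cells (Homo sapiens) for inhibition, read by trypan blue exclusion, with a stated time of 96 h (a higher number here means a weaker inhibitor of growth, a lower number a stronger inhibitor of growth), compound 1 (`O=C(/C(=C\c1c(O)cc(O)cc1O)S(=O)(=O)c1ccccc1Br)c1ccc(Cl)cc1`) sits at 50000 nM and is the high number of the group. Compound 2 (`O=C(O)c1ccc(C(=O)/C(=C\c2ccc(Cl)c([N+](=O)[O-])c2)SCc2ccc(C(F)(F)F)cc2)cc1`) reads 1000 nM and compound 3 (`O=C(/C(=C\c1ccc(Cl)cc1)Sc1ccc(Cl)cc1)c1ccc(Cl)cc1`) reads 1000 nM so these two stand level. Together they hold the lowest of the three numbers, and compound 3 lies well beyond the scatter from compound 1.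

Compound 4 (`O=C(/C(=C\c1ccc(Cl)cc1)SCc1ccc(F)cc1)c1ccc(Cl)cc1`) has not yet been measured. It carries 4-fluorobenzyl in place of the 4-chlorophenyl on the sulfur of compound 3 (4-fluorobenzyl in place of 4-chlorophenyl on a sulfur) and is otherwise the same. Going by the values given here, no step between measured compounds bears directly on this swap. Compound 2 also has a benzyl group on a sulfur and reads 1000 nM so a benzyl group there is not expected to cost much in this assay. An estimated 1.4-fold lower number from compound 3 to compound 4 (0.15 log units; within the scatter) is expected, small and probably within the scatter, leaning toward stronger inhibition of growth. The value expected for compound 4 is 700 nM (estimated range 200 nM to 2500 nM).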

Compound 4, concentration for 50% growth inhibition: 10000 nM
Compound 4: the middle estimate sits 14-fold (1.15 log units) below what was measured; measured number above the stated range.
By their numbers in this assay, from the lowest: compounds 2 and 3 (each within the scatter of the next); then compound 4; then compound 1.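

In this assay, the group on the sulfur of the shared core proves to matter: 4-fluorobenzyl in place of 4-chlorophenyl gives a 10-fold higher number from compound 3 to compound 4 (1.00 log units; beyond the scatter), the first single-place change among the compounds shown and one that lies beyond the scatter. Compound 2 also carries a benzyl group on its sulfur but differs from compound 4 in several other places, so it gives no direct reading of this change. Nothing among the data given accounts for the step.

The compounds shown leave open whether the step follows from the benzyl link or from fluorine in place of chlorine, as the two change together. They also leave open how 4-chlorobenzyl, an amine or a longer chain on this sulfur would read in this assay.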